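Replacing the Acid Hydroxy with a Phosphorus-Bearing Chain

The compounds below may be only part of what the source reports. "The series", "measured", "known", "first", "only" and "open" are said of these compounds alone.

Three measured compounds share one core and differ only in the arm attached to the nitrogen on the aromatic ring. Compound 1 `CC(C)c1onc(-c2c(Cl)cccc2Cl)c1COc1ccc(N(C)C(=O)c2ccc(C(=O)O)cc2)c(C(F)(F)F)n1` carries a (4-carboxyphenyl)carbonyl there, and in a functional assay on HEK293 cells for agonist activity at Bile acid receptor (Homo sapiens), read by a luciferase reporter (a higher number here means that more compound is needed for the effect, a lower number that less compound is needed), compound 1 gives 208 nM. Compound 2 `CC(C)c1onc(-c2c(Cl)cccc2Cl)c1COc1ccc(N(C)Cc2cccc(C(=O)O)c2)c(C(F)(F)F)n1` carries a 3-carboxybenzyl instead, and in this assay compound 2 gives 6 nM, the lowest of the three numbers. Compound 3 `CC(C)c1onc(-c2c(Cl)cccc2Cl)c1COc1ccc(N(C)Cc2ccc(OCC(=O)O)cc2)c(C(F)(F)F)n1` carries a 4-(carboxymethoxy)benzyl, and in this assay compound 3 gives 19 nM. The steps are a 35-fold lower number from compound 1 to compound 2 (1.54 log units; beyond the scatter) and a 3.2-fold higher number from compound 2 to compound 3 (0.50 log units; beyond the scatter); the remaining comparison is an 11-fold lower number from compound 1 to compound 3 (1.04 log units; beyond the scatter).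

Compound 4 `CC(C)c1onc(-c2c(Cl)cccc2Cl)c1COc1ccc(N(C)Cc2cccc(C(=O)NCCOP(=O)(O)O)c2)c(C(F)(F)F)n1` keeps the arm of compound 2 but alters its end: a group of 8 heavy atoms (2 carbon, 1 nitrogen, 4 oxygen, 1 phosphorus; no ring) in place of one oxygen atom, on a carbonyl carbon. The carboxy group thus becomes an amide carrying a chain with phosphorus and oxygen atoms at its end. Among the measured compounds shown here, no measured pair shows exactly this change. The most relevant guide is a 3.2-fold higher number from compound 2 to compound 3 (0.50 log units; beyond the scatter), where a short link was inserted before the carboxy group and the number rose modestly. The change in compound 4 adds far more atoms than that step did, so a larger rise is expected, though the outcome is uncertain. The estimate for compound 4 is 40 nM, with a range from 8 nM to 200 nM, corresponding to an expected step of a 6.7-fold higher number from compound 2 to compound 4 (0.82 log units; beyond the scatter).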

Compound 4, half-maximal effective concentration: 216 nM
Beside the measured number, compound 4's estimate is 5.4-fold (0.73 log units) below it, outside the stated range (above it).
By their numbers in this assay, from the lowest: compound 2; then compound 3; then compounds 1 and 4 (each within the scatter of the next).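

Replacing the hydroxy on the carbonyl carbon of the arm with the phosphorus-bearing chain gives a 36-fold higher number from compound 2 to compound 4 (1.56 log units; beyond the scatter) in this assay, a large step. Among the compounds shown here, compounds 1, 2 and 3 differ in how the arm is built, but all of them keep a carboxy group at its end, so this is the first result here to show how much the number depends on that end: the change at this single place raises the number well beyond the scatter, yet compound 4 still gives a measurable number in the same assay. Nothing measured here explains the rise.

This single step changes two things at once, turning the carboxy group into an amide and adding a chain with a phosphorus-bearing end, so the compounds shown do not reveal how much each part contributes. Going by these compounds, a simple primary amide, an amide whose two-carbon chain ends in a carboxylic acid, or one whose chain ends in a hydroxy group would each help to separate the two parts, and whether a longer chain would move the number further also remains open.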